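Swapping the Ester for an Isopentyl Ether

This account rests on a few compounds, and the source may have more. Where it says the series, first, only, none or still open, it means among the compounds named here.

Three compounds share one core and differ only at a single oxygen on an aromatic ring. Compound 1 `CCOc1ccc2oc(/C=C/[S+](C)[O-])cc(=O)c2c1` gives 1500 nM in a functional assay on A549 cells (Homo sapiens) for cytotoxicity, with a stated time of 48 h; a higher number here means a weaker inhibitor, a lower number a stronger inhibitor. Compound 2 `C[S+]([O-])/C=C/c1cc(=O)c2ccccc2o1` gives 1900 nM in this assay, and compound 3 `CCCC(=O)Oc1ccc2oc(/C=C/[S+](C)[O-])cc(=O)c2c1` gives 2200 nM. The three steps, a 1.3-fold higher number from compound 1 to compound 2 (0.10 log units; within the scatter), a 1.5-fold higher number from compound 1 to compound 3 (0.17 log units; within the scatter) and a 1.2-fold higher number from compound 2 to compound 3 (0.06 log units; within the scatter), all lie within the scatter, so compound 3 stands level with the other two. Compound 4 `CC(C)CCOc1ccc2oc(/C=C/[S+](C)[O-])cc(=O)c2c1` differs from compound 3 by isopentyl in place of propylcarbonyl on an oxygen on an aromatic ring. The step that also changed the group on that oxygen, a 1.5-fold higher number from compound 1 to compound 3 (0.17 log units; within the scatter), bears most on this and stayed within the scatter, so no step beyond the scatter is expected here. Compound 4 is therefore estimated at 1800 nM, within a range from 900 nM to 3600 nM. This expectation amounts to a 1.2-fold lower number from compound 3 to compound 4 (0.09 log units; within the scatter).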

Compound 4, half-maximal inhibitory concentration: 1000 nM
Compound 4: the middle estimate sits 1.8-fold (0.26 log units) above what was measured; the range from low to high includes it.
By their numbers in this assay, from the lowest: compounds 4, 1, 2 and 3 (each within the scatter of the next, the first and the last beyond it).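

In this assay, among these compounds, the isopentyl ether on this oxygen gives the first step beyond the scatter, though a modest one, against the ester (a 2.2-fold lower number from compound 3 to compound 4 (0.34 log units; beyond the scatter)). Among the compounds shown here, the same ether stands level with hydrogen on that aromatic carbon (a 1.9-fold lower number from compound 2 to compound 4 (0.28 log units; within the scatter)) and with the ethyl ether (a 1.5-fold lower number from compound 1 to compound 4 (0.18 log units; within the scatter)), both steps within the scatter, so only the pair of ester and isopentyl ether is told apart here. Nothing shown here accounts for this step. On these data alone, whether an amine or a carboxylic acid at the end of the chain on this oxygen would keep the number at this level remains open.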